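The compounds below may be only part of what the source reports. "The series", "measured", "known", "first", "only" and "open" are said of these compounds alone.

In a functional assay on DU-145 cells (Homo sapiens) for inhibition, read by trypan blue exclusion, with a stated time of 96 h (on this read-out lower numbers stand for stronger inhibition of growth and higher numbers for weaker inhibition of growth), compound 1 `CN(C)c1ccc(/C=C(/SCc2ccccc2Cl)C(=O)c2ccc(Cl)cc2)cc1` gives > 100000 nM as a limit of the assay and not a number. Compound 2 `CN(C)c1ccc(/C=C(\C(=O)c2ccc(Cl)cc2)S(=O)(=O)c2ccc(Br)cc2)cc1` gives > 100000 nM as a limit too. Compound 2 thus stands at the limit of > 100000 nM in this assay, at which 2 of the 2 values shown sit, and has no number of its own. Compound 3 `CN(C)c1ccc(/C=C(/SCc2ccc(Cl)cc2Cl)C(=O)c2ccc(Cl)cc2)cc1` keeps the shared core and differs from compound 2 at one place, a double-bonded chain carbon bound to a carbonyl carbon and a double-bonded chain carbon, by (2,4-dichlorobenzyl)sulfanyl in place of (4-bromophenyl)sulfonyl on a double-bonded chain carbon bound to a carbonyl carbon and a double-bonded chain carbon and by nothing else. Going by the values given here, the one measured step at this place is a step that the two limits leave unreadable from compound 1 to compound 2 and it offers no size to carry over. Compound 3 is expected to resemble compound 1, which carries the (2-chlorobenzyl)sulfanyl and gives > 100000 nM as a limit. Among the compounds with values here, with no measured step pointing either way, no change beyond the scatter is expected, and a number no higher from compound 2 to compound 3 (the limit leaves the size open) is the estimated step, with no direction claimed. Compound 3 is estimated at 100000 nM with a range of 30000 nM to 200000 nM and may well return only a limit.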

Compound 3, concentration for 50% growth inhibition: 50000 nM
Beside the measured number, compound 3's estimate is 2.0-fold (0.30 log units) above it; the measured number falls inside the stated range.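

In this assay, going by these compounds alone, compound 3 gives 50000 nM, the first value at this place that is a number and not a limit, so a group on a double-bonded chain carbon bound to a carbonyl carbon and a double-bonded chain carbon can bring the reading inside the range of the assay. Set against the (4-bromophenyl)sulfonyl group, the change reads as an at least 2.0-fold lower number from compound 2 to compound 3 (0.30 log units; that floor lies within the scatter), and set against the (2-chlorobenzyl)sulfanyl group, the added chloro reads as an at least 2.0-fold lower number from compound 1 to compound 3 (0.30 log units; that floor lies within the scatter); both are only floors that lie within the scatter, so neither establishes a real gain by itself. The other two compounds remain at the ceiling: the limit of > 100000 nM in this assay, at which 2 of the 3 values shown sit.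

From the compounds shown here alone, how far either step truly reaches stays open, since the two compounds on the far side of these steps have limits and not numbers of their own. Also open, going by these compounds, is whether a benzylsulfanyl group carrying methoxy or an amine on its ring in place of the chloro groups would give a number lower than that of compound 3.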